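Carboxy to methoxycarbonyl: notes on compound 3

A few compounds are considered here, and "the series" means these few. Any claim that something is new, unique, unknown or untested is made for them only; others in the source may bear on it.

Measured in a functional assay on MCF7 cells (Homo sapiens) for inhibition, read by sulforhodamine B assay, with a stated time of 72 h; a higher number here means a weaker inhibitor of growth, a lower number a stronger inhibitor of growth:
- compound 1 `NNC(=O)CCc1ccncc1-c1ccc2ccccc2c1`: > 10000 nM, a limit
- compound 2 `CCOC(=O)/C=C/c1ccncc1-c1ccc2[nH]ccc2c1`: > 10000 nM, a limit
- compound 3 `O=C(O)/C=C/c1ccncc1-c1ccc2ccccc2c1`: > 10000 nM, a limit

Going by the values given here, no compound in this set has a number yet; the whole set stands at the limit of > 10000 nM in this assay, at which 3 of the 3 values shown sit. Compound 3 therefore has no position to rank, and in this assay compound 3 is held only by the limit > 10000 nM.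

Compound 4 `COC(=O)/C=C/c1ccncc1-c1ccc2ccccc2c1` differs from compound 3 by methyl in place of hydrogen on an oxygen next to a carbonyl group. This is methyl in place of hydrogen on an oxygen next to a carbonyl group, which turns carboxy into methoxycarbonyl.

Among the compounds with values here, the only measured step touching compound 3 is a step that the two limits leave unreadable from compound 1 to compound 3. It involves another change at the same group and gives no size to carry over. Within the data shown here, no measured step covers the change from carboxy to methoxycarbonyl. With no size and no direction to draw on, no step beyond the scatter is expected in this assay, and a report as a limit alone is the likeliest outcome.

The expected step is a step that the limit leaves unreadable from compound 3 to compound 4.

For compound 4 the estimated value is 15000 nM, with an expected range of 5000 nM to 40000 nM.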

Compound 4, concentration for 50% growth inhibition: 8170 nM
For compound 4 the middle estimate is 1.8-fold (0.26 log units) above the measured one; the measured number falls inside the stated range.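

In this assay compound 4 gives 8170 nM, the only number in the set shown. The other values are limits of the assay, not numbers: the limit of > 10000 nM in this assay, at which 3 of the 4 values shown sit.

Carboxy to methoxycarbonyl gives an at least 1.2-fold lower number from compound 3 to compound 4 (0.08 log units; that floor lies within the scatter), and 2-(aminocarbamoyl)ethyl to 2-(methoxycarbonyl)ethenyl gives an at least 1.2-fold lower number from compound 1 to compound 4 (0.08 log units; that floor lies within the scatter); both are floors rather than sizes, so the result places methoxycarbonyl on a measurable footing at this position without showing that either change moves growth inhibition beyond the scatter.

From the compounds shown here alone, the true size of both steps stays open, as does whether the number depends on the methyl on this oxygen specifically or would persist with a longer chain on the ester, a primary amide or an amine in place of methoxycarbonyl. Steps between two limits cannot be read, so the shown compounds give no order among those that carry limits and no sign of how far this position can go in this assay.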